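The source may report more compounds than this note shows. Statements on the series, on what has been measured and on what is new or still open speak of the compounds shown alone.

Three members of the series have half-lives in hand. Compound 1 `CC/C(=C\C(=N\O)C(N)=O)C(C(C)C)[N+](=O)[O-]` gives 11.5 h in an ADME assay for pharmacokinetics; on this read-out lower numbers stand for a shorter-lived compound and higher numbers for a longer-lived compound; compound 2 `CC/C(=C\C(=N\O)C(N)=O)C([N+](=O)[O-])C(C)(C)C` gives 48.3 h; compound 3 `CC/C(=C\C(CNC(=O)c1cccnc1)=N\O)C(CC)[N+](=O)[O-]` gives 5.83 h, which stands within the scatter of compound 1 and beyond it from compound 2. Among the compounds with values here, the one counted step so far is a 4.2-fold lower number from compound 2 to compound 1 (0.62 log units; beyond the scatter), the change being (hydrogen in place of methyl on a saturated chain carbon bound to three saturated chain carbons), read one bond further out as tert-butyl to isopropyl. The core of compound 3 and the core of compound 2 differ in a way that is not broken down here.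

Compound 4 `CCC(/C(C)=C/C(CNC(=O)c1cccnc1)=N/O)[N+](=O)[O-]` is not yet measured. It differs from compound 3 by hydrogen in place of methyl on a saturated chain carbon bound to a double-bonded chain carbon, read one bond further out as ethyl to methyl. Within the data shown here, this is the same kind of change as the one from compound 2 to compound 1, not the same: there the place is a saturated chain carbon bound to three saturated chain carbons, here a saturated chain carbon bound to a double-bonded chain carbon. The step of a 1.5-fold lower number from compound 3 to compound 4 (0.16 log units; within the scatter) is therefore expected to be smaller than a 4.2-fold lower number from compound 2 to compound 1 (0.62 log units; beyond the scatter), since only the kind of change carries over. Compound 4 is estimated at 4 h, between 1.8 h and 8.5 h.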

Compound 4, half-life: 5.83 h
Beside the measured number, compound 4's estimate is 1.5-fold (0.16 log units) below it; the measured number falls inside the stated range.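

Hydrogen in place of methyl does not carry over as one fixed step in this assay, and the gap between the two cores exceeds what repeat measurements would explain: the same change on two cores in this assay, a 4.2-fold lower number (0.62 log units; beyond the scatter) from compound 2 to compound 1 and no change at the digits printed (within the scatter) from compound 3 to compound 4, 4.2-fold (0.62 log units) apart, beyond the scatter of two such steps. On the core of compound 3, the step reads no change at the digits printed from compound 3 to compound 4 (within the scatter), so the size of the step on the core of compound 2 gives no guide to this core. This does not show whether the core or the place accounts for the gap: the place also differs, being a saturated chain carbon bound to three saturated chain carbons in one step and a saturated chain carbon bound to a double-bonded chain carbon in the other, and two steps set no rule for the series.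

The compounds shown leave open how the same change behaves at one and the same place on both cores. They also leave open whether a longer chain, an amine or a carboxylic acid in place of that methyl would move the half-life on the core of compound 3.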